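The source may hold more compounds than are shown below. What is called first, only, known or untested is meant among the compounds shown, and "the series" means these compounds.

Compound 2 `CS/C(=N\C(=O)c1ccco1)NC(=O)c1ccco1` and compound 1 `CS/C(=N\C(=O)c1csc([N+](=O)[O-])c1)NC(=O)c1csc([N+](=O)[O-])c1` are built on two different cores, and the difference between those cores is not broken down here. In a functional assay on K562 cells (Homo sapiens) for cytotoxicity, read by MTT assay, with a stated time of 72 h (on this read-out lower numbers stand for stronger inhibition of growth and higher numbers for weaker inhibition of growth), compound 2 gives 64800 nM, and compound 1 gives 56900 nM, two numbers that lie within the scatter of each other. Compound 3 `O=C(/N=C(/NC(=O)c1ccco1)[Se]Cc1ccccc1)c1ccco1` differs from compound 2 by a group of 8 heavy atoms (7 carbon, 1 selenium; one six-membered aromatic ring of carbon only) in place of a group of 2 heavy atoms (1 carbon, 1 sulfur; no ring), on a carbon with a double bond to nitrogen, and in this assay compound 3 gives 9530 nM, which is a 6.8-fold lower number from compound 2 to compound 3 (0.83 log units; beyond the scatter). Compound 4 `O=C(/N=C(/NC(=O)c1csc([N+](=O)[O-])c1)[Se]Cc1ccccc1)c1csc([N+](=O)[O-])c1` carries the same change on the core of compound 1: a group of 8 heavy atoms (7 carbon, 1 selenium; one six-membered aromatic ring of carbon only) in place of a group of 2 heavy atoms (1 carbon, 1 sulfur; no ring), on a carbon with a double bond to nitrogen. For compound 4 the step in this assay is expected to be a 5.7-fold lower number from compound 1 to compound 4 (0.76 log units; beyond the scatter), set beside the earlier one, because a 6.8-fold lower number from compound 2 to compound 3 (0.83 log units; beyond the scatter) was seen when the same change was made on the other core. Compound 4 is therefore estimated at 10000 nM, with a likely range from 3000 nM to 35000 nM.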

Compound 4, concentration for 50% growth inhibition: 23500 nM
Estimate against measurement, compound 4: 2.4-fold (0.37 log units) below; measured number inside the range.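

In this assay, putting the selenium-bearing group with its six-membered aromatic ring in place of methylsulfanyl again goes in the same direction on the core of compound 1, giving a 2.4-fold lower number from compound 1 to compound 4 (0.38 log units; beyond the scatter). The direction therefore holds on both cores shown, but the size of the step does not carry over intact: the same change on two cores in this assay, a 6.8-fold lower number (0.83 log units; beyond the scatter) from compound 2 to compound 3 and a 2.4-fold lower number (0.38 log units; beyond the scatter) from compound 1 to compound 4, 2.8-fold (0.45 log units) apart, beyond the scatter of two such steps. These two cores are a single comparison, so the result gives no reason for the gap and does not show how the change would behave on any other core.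

The compounds shown leave open how much of each step belongs to the selenium and how much to the ring. They also leave open how a longer alkyl chain or an amine would read on the same carbon.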